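This account rests on a few compounds, and the source may have more. Where it says the series, first, only, none or still open, it means among the compounds named here.

Measured compounds:
- compound 1, `CN1CCN(c2nc(Nc3ccc(C#N)c(C(F)(F)F)c3)nc(Oc3ccnc4ccccc34)n2)CC1` — 51200 nM
- compound 2, `N#Cc1ccc(Nc2nc(Oc3ccnc4ccccc34)nc(N3CCN(c4cccc(C(F)(F)F)c4)CC3)n2)cc1C(F)(F)F` — 38700 nM

In a functional assay on DU-145 cells (Homo sapiens) for cytotoxicity, read by sulforhodamine B assay, with a stated time of 48 h (a lower number here means a stronger inhibitor of growth, a higher number a weaker inhibitor of growth), compound 2 gives 38700 nM, and compound 1 gives 51200 nM; the two numbers lie within the scatter of each other, so neither compound stands apart from the other on this assay. Within the data shown here, the only measured step, a 1.3-fold lower number from compound 1 to compound 2 (0.12 log units; within the scatter), is therefore too small to read as a real change.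

Compound 3, `CCN1CCN(c2nc(Nc3ccc(C#N)c(C(F)(F)F)c3)nc(Oc3ccnc4ccccc34)n2)CC1`, has not yet been measured. It differs from compound 2 in one place: ethyl in place of 3-(trifluoromethyl)phenyl on an amine nitrogen in a ring. The measured step bears on this directly, since it exchanges the same ring nitrogen's group the other way, from methyl to the aryl group; that step, a 1.3-fold lower number from compound 1 to compound 2 (0.12 log units; within the scatter), stayed within the scatter. Returning to a small alkyl group is therefore expected to give, at most, a step of similar size in this assay, and none that would clearly exceed the scatter.

The estimate for compound 3 is 48000 nM (range 20000 nM to 110000 nM), the expected step being a 1.2-fold higher number from compound 2 to compound 3 (0.09 log units; within the scatter).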

Compound 3, concentration for 50% growth inhibition: 86600 nM
The estimate for compound 3 lay 1.8-fold (0.26 log units) below the measured number, within the range that was stated.
By their numbers in this assay, from the lowest: compounds 2, 1 and 3 (each within the scatter of the next, the first and the last beyond it).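

Among these compounds, on the amine nitrogen in the ring, replacing the 3-(trifluoromethyl)phenyl group with ethyl gives the first step here that passes the scatter in this assay (a 2.2-fold higher number from compound 2 to compound 3 (0.35 log units; beyond the scatter)), so the group on this nitrogen can register in this read-out, if only modestly, which the earlier exchange of methyl for the aryl group could not show. The two small alkyl groups are not told apart, since the added carbon leaves the pair within the scatter (a 1.7-fold higher number from compound 1 to compound 3 (0.23 log units; within the scatter)), and the only separation seen is therefore that between ethyl and the aryl group, not a general one between alkyl and aryl groups. The data shown offer nothing that explains this separation.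

Going by these compounds, whether an unsubstituted phenyl, a benzyl group or a longer chain such as butyl on this nitrogen would fall with ethyl or with the 3-(trifluoromethyl)phenyl group remains open. On these data alone, it is also open whether a hydroxyethyl chain or an acetyl group here would give a step beyond the scatter, and whether the step between ethyl and the aryl group would hold on a different core.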